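The source may report more compounds than this note shows. Statements on the series, on what has been measured and on what is new or still open speak of the compounds shown alone.

Compounds measured so far:
Compound 1 `COc1ccc(OC)c(/C=N/NC(=O)Nc2ccc(Oc3ccnc(-c4nncn4CCN(C)C)c3)c(F)c2)c1` — in a functional assay on U-87MG ATCC cells (Homo sapiens) for cytotoxicity, read by MTT assay, with a stated time of 72 h (on this read-out lower numbers stand for stronger inhibition and higher numbers for weaker inhibition), compound 1 gives 6400 nM.
Compound 2 `CN(C)CCn1cnnc1-c1cc(Oc2ccc(NC(=O)N/N=C/c3cccc(O)c3)cc2F)ccn1` — compound 2 reaches only a limit of this assay, > 100000 nM.
Compound 3 `CN(C)CCn1cnnc1-c1cc(Oc2ccc(NC(=O)N/N=C/c3ccc(Cl)cc3)cc2F)ccn1` — compound 3 gives 1370 nM.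

Compound 3 stands lowest of the two numbers shown; its nearest neighbour is compound 1, with a 4.7-fold lower number from compound 1 to compound 3 (0.67 log units; beyond the scatter). Compound 2 sits at the limit of > 100000 nM in this assay, at which 1 of the 3 values shown sits.

Compound 4 `CN(C)CCn1cnnc1-c1cc(Oc2ccc(NC(=O)N/N=C/c3cccc(Cl)c3Cl)cc2F)ccn1` is not yet measured. It differs from compound 3 in one place: 2,3-dichlorophenyl in place of 4-chlorophenyl on a carbon with a double bond to nitrogen.

All three measured steps change the aryl group on the carbon with a double bond to nitrogen. Two of them are large: an at least 15-fold higher number from compound 1 to compound 2 (1.19 log units; beyond the scatter) and an at least 72-fold lower number from compound 2 to compound 3 (1.86 log units; beyond the scatter). One is modest: a 4.7-fold lower number from compound 1 to compound 3 (0.67 log units; beyond the scatter). None of them exchanges one chlorophenyl for another chlorophenyl, so the change from compound 3 to compound 4 has no direct precedent among the shown compounds; the measured steps only show that this position tolerates wide swings when the aryl group changes.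

Compound 4 is therefore expected to stay close to compound 3, with a step of a 1.1-fold higher number from compound 3 to compound 4 (0.04 log units; within the scatter) that may well fall within the scatter. The estimate for compound 4 is 1500 nM, within a range from 500 nM to 5000 nM.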

Compound 4, half-maximal inhibitory concentration: 13200 nM
Beside the measured number, compound 4's estimate is 8.8-fold (0.94 log units) below it, outside the stated range (above it).
By their numbers in this assay, from the lowest: compound 3; then compound 1; then compound 4. At a limit, above all of these: compound 2.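

In this assay, going by these compounds alone, the first exchange of one chlorophenyl for another shows that this position on the carbon with a double bond to nitrogen responds to the chlorine pattern itself, with a 9.6-fold higher number from compound 3 to compound 4 (0.98 log units; beyond the scatter); the 2,3-dichlorophenyl group also gives up the lead that the 4-chlorophenyl group held over the 2,5-dimethoxyphenyl group, with a 2.1-fold higher number from compound 1 to compound 4 (0.31 log units; beyond the scatter). Chlorine on the aryl group is therefore not enough on its own to give the lowest number in this set, although the 2,3-dichlorophenyl group still stays clear of the 3-hydroxyphenyl group, with an at least 7.5-fold lower number from compound 2 to compound 4 (0.87 log units; beyond the scatter). Compound 2 gives a limit of the assay and not a number, so that last step is only a bound: the limit of > 100000 nM in this assay, at which 1 of the 4 values shown sits.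

The change from 4-chlorophenyl to 2,3-dichlorophenyl alters both the number of chlorine atoms and their placement, and the compounds shown do not separate these two changes. They also leave open how a plain phenyl, a bromophenyl or a pyridyl group would compare at this position.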